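Liver microsome stability of a cyanopyridinyl amine analogue

The source may hold more compounds than are shown below. What is called first, only, known or untested is meant among the compounds shown, and "the series" means these compounds.

Measured so far in an ADME assay on microsomes from liver (Homo sapiens) for metabolic stability, read by LC-MS, with a stated time of 30 min, tested at 0.1 uM; on this read-out higher numbers stand for a more stable compound and lower numbers for a less stable compound:
- compound 1 `COc1ccnc(Nc2cc3[nH]c(-c4cccc(C(F)(F)F)c4)nc3cn2)c1`: compound 1 gives 80%
- compound 2 `FC(F)(F)c1cccc(-c2nc3cnc(Nc4ccncn4)cc3[nH]2)c1`: compound 2 gives 90%

Both measured compounds share one core and differ only in the ring attached to the amine nitrogen. Compound 2 carries the pyrimidinyl ring and gives the higher of the two numbers, but the step of a number 10 percentage points higher from compound 1 to compound 2 (within the scatter) is within the scatter, so compound 1 and compound 2 cannot be told apart on this read-out.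

Compound 3 `N#Cc1ccc(Nc2cc3[nH]c(-c4cccc(C(F)(F)F)c4)nc3cn2)nc1` is not yet measured. It differs from compound 2 in the change 5-cyanopyridin-2-yl in place of pyrimidin-4-yl on a nitrogen on an aromatic ring: the pyrimidinyl ring leaves and a 5-cyanopyridin-2-yl ring, with its nitrile, enters at the same nitrogen. Within the data shown here, the only measured step that touches this position is a number 10 percentage points higher from compound 1 to compound 2 (within the scatter), and it stayed within the scatter. On that basis the step of a number 10 percentage points lower from compound 2 to compound 3 (within the scatter) is expected to be small, with no clear direction beyond the scatter. Compound 3 is therefore expected to give about 80% in this assay, with a range from 60% to 95%.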

Compound 3, percent of the compound remaining: 39%
Beside the measured number, compound 3's estimate is 41 percentage points above it; the measured number lies below the stated range.
By their numbers in this assay, from the lowest: compound 3; then compounds 1 and 2 (each within the scatter of the next).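

In this assay, the group on this nitrogen can clearly matter: 5-cyanopyridin-2-yl in place of pyrimidin-4-yl gives a number 51 percentage points lower from compound 2 to compound 3 (beyond the scatter), whereas the earlier change at this position stayed within the scatter. The same holds against the other earlier compound, with 5-cyanopyridin-2-yl in place of 4-methoxypyridin-2-yl giving a number 41 percentage points lower from compound 1 to compound 3 (beyond the scatter), so a pyridin-2-yl ring alone does not go with the low number, since compound 1 also carries one and sits with compound 2. Nothing measured here explains why the stability differs so much between these groups.

The compounds shown leave open whether the low number goes with the nitrile itself or with where it sits on the ring. A plain pyridin-2-yl ring, or a 5-chloropyridin-2-yl ring, on this nitrogen would help separate those two readings.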